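Butylamino in place of chloro on compound 1

This account rests on a few compounds, and the source may have more. Where it says the series, first, only, none or still open, it means among the compounds named here.

Compound 1 `C=CCOc1ccc(C(=O)Nc2cccc(Cl)n2)cc1` was tested in an in vitro assay on HEK-tsA201 cells for antagonist activity at Neuronal acetylcholine receptor; alpha4/beta2 (Homo sapiens), read by fluorescence and calcium flux (on this read-out higher numbers stand for weaker inhibition and lower numbers for stronger inhibition), where compound 1 gives > 100000 nM, which is a limit of the assay rather than a number. Compound 2 `CCCOc1ccc(C(=O)Nc2cccc(Cl)n2)cc1` likewise gives > 100000 nM, also a limit. Compound 3 `CCCOc1ccc(C(=O)Nc2cccc(Nc3ccccc3F)n2)cc1` gives > 100000 nM, again a limit. The step that the two limits leave unreadable from compound 1 to compound 2 and the step that the two limits leave unreadable from compound 2 to compound 3 cannot be read because of the limit of > 100000 nM in this assay, at which 3 of the 3 values shown sit. Compound 4 `C=CCOc1ccc(C(=O)Nc2cccc(NCCCC)n2)cc1` differs from compound 1 by butylamino in place of chloro on an aromatic carbon. For the measured compounds named here, no measured step covers this exact change; the nearest, from compound 2 to compound 3, put (2-fluorophenyl)amino in place of chloro and stayed at the limit. Compound 4 is therefore expected to stay at the limit as well, an expected step of a number no higher from compound 1 to compound 4 (the limit leaves the size open). The estimated value for compound 4 is 100000 nM, ranging from 30000 nM to 300000 nM.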

Compound 4, half-maximal inhibitory concentration: 22400 nM
Estimate against measurement, compound 4: 4.5-fold (0.65 log units) above; measured number below the stated range.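

Butylamino in place of chloro gives an at least 4.4-fold lower number from compound 1 to compound 4 (0.64 log units; beyond the scatter) in this assay. This shows that a change at this aromatic carbon, next to the ring nitrogen, can bring the series off the limit, and compound 4 is the only compound shown with a readable number. The earlier steps cannot be read: the limit of > 100000 nM in this assay, at which 3 of the 4 values shown sit.

As far as these compounds go, whether the stronger inhibition depends on the amino nitrogen or on the chain stays open; a pentyl group or a longer hexylamino chain at this position would help separate the two. Also open, from the compounds shown here alone, is whether the allyl ether of compound 4 matters once butylamino is present.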